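Bromo substitution on two cores at the sigma-1 receptor

The source may report more compounds than this note shows. Statements on the series, on what has been measured and on what is new or still open speak of the compounds shown alone.

Compound 1 `CN(CCCn1c(=O)sc2ccccc21)Cc1ccccc1`: 10.3 nM in an assay on Jurkat cells for displacement of a labelled ligand from Sigma non-opioid intracellular receptor 1 (Homo sapiens), read by scintillation counting, with a stated time of 120 min; on this read-out higher numbers stand for weaker inhibition and lower numbers for stronger inhibition.
Compound 2 `CN(CCCn1c(=O)sc2ccc(Br)cc21)Cc1ccccc1`: 3.1 nM in this assay.
Compound 3 `O=c1oc2ccccc2n1CCCN1Cc2ccccc2C1`: in this assay compound 3 gives only a limit of the assay, > 100 nM.

From compound 1 to compound 2 the change is bromo in place of hydrogen on an aromatic carbon. It brought a 3.3-fold lower number from compound 1 to compound 2 (0.52 log units; beyond the scatter). Compound 4 `O=c1oc2cc(Br)ccc2n1CCCN1Cc2ccccc2C1` carries the same change on the core of compound 3: bromo in place of hydrogen on an aromatic carbon. How the core of compound 3 differs from that of compound 1 is not broken down here. Since compound 3 sits at the limit of > 100 nM in this assay, at which 1 of the 3 values shown sits, the starting point for this second step is known only as a limit. Taking the measured step as a guide, the step from compound 3 to compound 4 is expected to be an at least 1.2-fold lower number from compound 3 to compound 4 (0.09 log units; that floor lies within the scatter). Compound 4 is therefore estimated to give 80 nM in this assay, between 25 nM and 300 nM.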

Compound 4, inhibition constant: > 100 nM
Compound 4: a limit, no number; the forecaster's own chance of this, stated with the estimate: 45%; middle value at least 1.2-fold (0.09 log units) from the limit.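

Compound 3 and compound 4 both rest on a limit of the assay in this assay, so the step between them cannot be read: the limit of > 100 nM in this assay, at which 2 of the 4 values shown sit. As far as these compounds go, whether bromo in place of hydrogen changes the number on the core of compound 3 stays open.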